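Switching the aryl-nitrogen heteroaryl of compound 3

The source may report more compounds than this note shows. Statements on the series, on what has been measured and on what is new or still open speak of the compounds shown alone.

In an assay on HEK293 cells for inhibition of Nitric oxide synthase, inducible (Homo sapiens), read by fluorescence (on this read-out higher numbers stand for weaker inhibition and lower numbers for stronger inhibition), compound 1 `O=c1cc(CN(c2cccnc2)c2cccc(Cl)c2)c2ccc(F)c(F)c2[nH]1` gives 77 nM, compound 2 `O=c1cc(CN(c2cccc(Cl)c2)c2ccncn2)c2ccc(F)c(F)c2[nH]1` gives 14 nM, and compound 3 `Cc1cccnc1N(Cc1cc(=O)[nH]c2c(F)c(F)ccc12)c1cccc(Cl)c1` gives 350 nM, the highest number of the three. The steps of a 4.5-fold higher number from compound 1 to compound 3 (0.66 log units; beyond the scatter) and a 25-fold higher number from compound 2 to compound 3 (1.40 log units; beyond the scatter) both run toward weaker inhibition, and compound 2 is the strongest of the set, as a 5.5-fold lower number from compound 1 to compound 2 (0.74 log units; beyond the scatter) shows.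

Compound 4 `COc1cc(N(Cc2cc(=O)[nH]c3c(F)c(F)ccc23)c2cccc(Cl)c2)ncn1` differs from compound 3 by 6-methoxypyrimidin-4-yl in place of 3-methylpyridin-2-yl on a nitrogen on an aromatic ring. Among the measured compounds shown here, this returns to the pyrimidin-4-yl arrangement of compound 2, now carrying a methoxy group; the methoxy has no measured precedent here. The step of a 25-fold higher number from compound 2 to compound 3 (1.40 log units; beyond the scatter) is therefore expected to be largely reversed, and the expected step is a 14-fold lower number from compound 3 to compound 4 (1.15 log units; beyond the scatter). For compound 4 in this assay the estimate is 25 nM, with a range of 8 nM to 80 nM.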

Compound 4, half-maximal inhibitory concentration: 61 nM
Beside the measured number, compound 4's estimate is 2.4-fold (0.39 log units) below it; the measured number falls inside the stated range.
By their numbers in this assay, from the lowest: compound 2; then compounds 4 and 1 (each within the scatter of the next); then compound 3.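

The step of a 4.4-fold higher number from compound 2 to compound 4 (0.64 log units; beyond the scatter) shows that methoxy in place of hydrogen on the pyrimidin-4-yl ring weakens inhibition, yet 6-methoxypyrimidin-4-yl still improves on 3-methylpyridin-2-yl, with a 5.7-fold lower number from compound 3 to compound 4 (0.76 log units; beyond the scatter) as the step. With a 1.3-fold lower number from compound 1 to compound 4 (0.10 log units; within the scatter) as the step, within the scatter, 6-methoxypyrimidin-4-yl and pyridin-3-yl cannot be told apart on this nitrogen. Nothing available gives a cause for these steps.

Open, on these data alone, is how an amine, a hydroxyl or a methyl in place of the methoxy on the pyrimidin-4-yl ring would read, and whether the loss seen with methoxy extends to them.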